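A few compounds are considered here, and "the series" means these few. Any claim that something is new, unique, unknown or untested is made for them only; others in the source may bear on it.

The measured compounds:
compound 1 `ClCc1cccc(Cn2cnc3ncnc(Cl)c32)c1` – 15100 nM
compound 2 `ClCc1cccc(Cn2cnc3c(Cl)ncnc32)c1` – 2130 nM
compound 3 `ClCc1ccc(Cn2cnc3nc(Cl)nc(Cl)c32)cc1` – 13200 nM

All three were tested in a functional assay on SW-620 cells (Homo sapiens) for cytotoxicity, read by sulforhodamine B assay, with a stated time of 48 h; on this read-out higher numbers stand for weaker inhibition of growth and lower numbers for stronger inhibition of growth. Compound 2 has the lowest of the three numbers; compound 3 gives a number above it by a gap beyond the scatter, and compound 1 gives one further above, also beyond the scatter. Compound 4 `ClCc1cccc(Cn2cnc3c(Cl)nc(Cl)nc32)c1` has not been measured in this assay. It differs from compound 2 by chloro in place of hydrogen on an aromatic carbon. Among the compounds with values here, no step between measured compounds isolates this change; compound 3 gives a higher number than compound 2, but it differs from compound 2 in more than one place. For compound 4 a small step toward a higher number is expected, a 1.9-fold higher number from compound 2 to compound 4 (0.27 log units; within the scatter). Compound 4 is expected to give 4000 nM, between 1000 nM and 16000 nM.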

Compound 4, concentration for 50% growth inhibition: 1580 nM
Beside the measured number, compound 4's estimate is 2.5-fold (0.40 log units) above it; the measured number falls inside the stated range.
By their numbers in this assay, from the lowest: compounds 4 and 2 (each within the scatter of the next); then compounds 3 and 1 (each within the scatter of the next).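

In this assay, within the data shown here, chloro in place of hydrogen on an aromatic carbon, between two ring nitrogen atoms, gives a 1.3-fold lower number from compound 2 to compound 4 (0.13 log units; within the scatter), the first step that isolates this change. The position therefore takes a chloro group with no shift in the read-out that stands clear of the scatter. Nothing measured here offers an explanation for this result.

Hydrogen and chloro are the only groups shown at this position, so it remains open whether an amine, a methoxy group or a longer chain there would also leave the number within the scatter.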